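The source may report more compounds than this note shows. Statements on the series, on what has been measured and on what is new or still open speak of the compounds shown alone.

Measured compounds:
- compound 1 `Oc1cccc(-c2cc(-c3ccncc3)nc(-c3cccc(Cl)c3)c2)c1`: "not determined" (no result reported) in an ADME assay on HEK293 cells (Homo sapiens) for cytotoxicity, read by CCK-8 assay and cell counting, with a stated time of 2 days; on this read-out higher numbers stand for weaker inhibition and lower numbers for stronger inhibition
- compound 2 `Oc1ccc(-c2cc(-c3ccncc3)nc(-c3cccc(Cl)c3)c2)cc1`: "not determined" (no result reported) in this assay
- compound 3 `Oc1cccc(-c2cc(-c3ccncc3)nc(-c3ccc(Cl)cc3)c2)c1`: 2890 nM

Compound 1 stands without a single number in this assay; compound 2 is the one further entry without a number. The only figure available comes from compound 3, which gives 2890 nM in this assay.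

Compound 4 `Oc1cccc(-c2cc(-c3ccccc3)nc(-c3cccc(Cl)c3)c2)c1` differs from compound 1 by phenyl in place of pyridin-4-yl on an aromatic carbon. For the measured compounds named here, no measured step between compounds that differ in one place exists for this series, so the size of the step into compound 4 is not known from data; the working assumption is no change beyond the usual scatter of this assay, with the direction open.

Compound 4 is expected to give about 3000 nM in this assay, within a range from 800 nM to 12000 nM.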

Compound 4, half-maximal inhibitory concentration: 3120 nM
The estimate for compound 4 lay 1.0-fold (0.02 log units) below the measured number, and the stated range covers the measured number.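

For the compounds shown here, compound 1 has no single number in this assay, so no step to compound 4 can be read. Going by these compounds, whether phenyl in place of pyridin-4-yl shifts the value stays open, and no evidence bears on this.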